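The source may hold more compounds than are shown below. What is called first, only, known or untested is meant among the compounds shown, and "the series" means these compounds.

In an assay (Rattus norvegicus) for inhibition of Fatty-acid amide hydrolase 1 (Homo sapiens) (on this read-out higher numbers stand for weaker inhibition and lower numbers for stronger inhibition), the measured compounds stand as follows:
- compound 1 `N#Cc1ccccc1-c1cnc(C(=O)CCCCCCc2ccccc2)o1` gives 130 nM
- compound 2 `Nc1cccc(-c2cnc(C(=O)CCCCCCc3ccccc3)o2)c1` gives 19 nM
- compound 3 `COC(=O)c1cccc(-c2cnc(C(=O)CCCCCCc3ccccc3)o2)c1` gives 12 nM

Compound 3 has the lowest number of the three; compound 2 sits within the scatter of it, whereas compound 1 lies well beyond. Compound 4 `N#Cc1cccc(-c2cnc(C(=O)CCCCCCc3ccccc3)o2)c1` differs from compound 3 by cyano in place of methoxycarbonyl on an aromatic carbon. Among the compounds with values here, two measured steps bear on this change. The step of a 6.8-fold lower number from compound 1 to compound 2 (0.84 log units; beyond the scatter) took a cyano away from one position and put an amino at the position now in question, with a modest gain. The step of a 1.6-fold lower number from compound 2 to compound 3 (0.20 log units; within the scatter) then exchanged amino for methoxycarbonyl at that same position without leaving the scatter, so this position has accepted two quite different groups at a similar level. Within the data shown here, no measured compound shows a cyano at this position directly. On that basis only a small step in this assay is expected, toward a higher number if anything, and most likely within the scatter. The estimate for compound 4 is 20 nM, with a range of 7 nM to 60 nM. The expected step of a 1.7-fold higher number from compound 3 to compound 4 (0.22 log units; within the scatter) is small.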

Compound 4, inhibition constant: 15 nM
Estimate against measurement, compound 4: 1.3-fold (0.12 log units) above, and the stated range covers the measured number.
By their numbers in this assay, from the lowest: compounds 3, 4 and 2 (each within the scatter of the next); then compound 1.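

A cyano group at this position sits level with the two groups seen there before in this assay: a 1.3-fold higher number from compound 3 to compound 4 (0.10 log units; within the scatter) and a 1.3-fold lower number from compound 2 to compound 4 (0.10 log units; within the scatter) both stay within the scatter, so amino, methoxycarbonyl and cyano cannot be ranked here. The third step isolates placement. Compound 1 and compound 4 carry the same nitrile and differ only in where it stands: an 8.7-fold lower number from compound 1 to compound 4 (0.94 log units; beyond the scatter) lies beyond the scatter, so the earlier gain from compound 1 did not depend on amino. Nothing at hand gives a reason for either finding.

On these data alone, it remains open whether a carboxylic acid or a longer chain at this position would stay level with compound 2, compound 3 and compound 4. Also open, as far as these compounds go, is whether amino or methoxycarbonyl placed as the nitrile is in compound 1 would give a similar loss.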